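Methoxy to hydroxy on a compound at the limit

The source may hold more compounds than are shown below. What is called first, only, known or untested is meant among the compounds shown, and "the series" means these compounds.

In an ADME assay on MCF7 cells (Homo sapiens) for cytotoxicity, with a stated time of 72 h (on this read-out lower numbers stand for stronger inhibition and higher numbers for weaker inhibition), compound 1 (`COc1ccc(CNc2ncnc3c2ncn3C2CCCCO2)cc1`) reads > 100000 nM as a limit and not as a number. In this assay compound 2 (`COc1cccc(CNc2ncnc3c2ncn3C2CCCCO2)c1O`) reads > 100000 nM as a limit and not as a number. Compound 2 thus stands at the limit of > 100000 nM in this assay, at which 2 of the 2 values shown sit, and gives no number against which a change could be measured. Going by the values given here, no step between measured compounds is available either.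

Compound 3 (`Oc1cccc(CNc2ncnc3c2ncn3C2CCCCO2)c1O`) keeps the shared core and differs from compound 2 in one place: hydrogen in place of methyl on an oxygen on an aromatic ring, which reads as methoxy to hydroxy (hydrogen in place of methyl on an oxygen on an aromatic ring). The expected size of the step is a number no higher from compound 2 to compound 3 (the limit leaves the size open) and none beyond the scatter is foreseen in this assay in either direction. This expectation rests on compound 2 with its > 100000 nM as a limit, so it is a loose one. Compound 3 is also expected to be reported quite possibly as a limit alone. For compound 3 the estimated value is 100000 nM with an expected range from 30000 nM to 200000 nM in this measurement.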

Compound 3, half-maximal inhibitory concentration: > 100000 nM
Compound 3 gave a limit, no number; the forecaster's own chance of this, stated with the estimate: 70%; the middle value lies on the limit itself.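

In this assay compound 3 reads > 100000 nM, a limit and not a number. Going by these compounds alone, neither the step from compound 2 to compound 3 nor the one from compound 1 to compound 3 can be read, as all three compounds share one limit: the limit of > 100000 nM in this assay, at which 3 of the 3 values shown sit. The compounds shown leave open whether methoxy to hydroxy changes this read-out at all, and by how much.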